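The source may hold more compounds than are shown below. What is called first, only, known or untested is meant among the compounds shown, and "the series" means these compounds.

Measured in a functional assay on the whole organism for inhibition, with Cavia porcellus as the target; on this read-out lower numbers stand for an effect already at smaller amounts and higher numbers for an effect only at larger amounts of compound:
- compound 1 `COc1ccccc1OCC1SCCN1C(=O)CNC(C)=O`: 40 mg/kg
- compound 2 `COc1ccccc1OCC1SCCN1C(=O)Cn1ccnc1`: 50 mg/kg
- compound 3 `COc1ccccc1OCC1SCCN1C(C)=O`: not yet measured

The two measured values do not separate. In this assay compound 2, at 50 mg/kg, lies within the scatter of compound 1.

The change from compound 2 to compound 3 is hydrogen in place of 1H-imidazol-1-yl on a saturated chain carbon bound to a carbonyl carbon. In words, this is hydrogen in place of 1H-imidazol-1-yl on a saturated chain carbon bound to a carbonyl carbon.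

Going by the values given here, only one measured step bears on this place: a 1.3-fold higher number from compound 1 to compound 2 (0.10 log units; within the scatter). It exchanges acetamido for 1H-imidazol-1-yl and stays within the scatter. Among the compounds with values here, that step swaps one substituent for another, whereas compound 3 carries no such substituent at all, and no measured compound shows the effect of hydrogen there. The evidence is therefore thin, and the range has to stay wide.

No step beyond the scatter is expected, and no direction can be favoured. The expected step is a 1.1-fold lower number from compound 2 to compound 3 (0.05 log units; within the scatter). For compound 3 the estimate is 45 mg/kg, with an expected range of 20 mg/kg to 120 mg/kg.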

Compound 3, dose for half-maximal effect: 46 mg/kg
Compound 3: the middle estimate sits 1.0-fold (0.01 log units) below what was measured, and the stated range covers the measured number.
By their numbers in this assay, from the lowest: compounds 1, 3 and 2 (each within the scatter of the next).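

In this assay hydrogen in place of 1H-imidazol-1-yl gives a 1.1-fold lower number from compound 2 to compound 3 (0.04 log units; within the scatter) and hydrogen in place of acetamido gives a 1.2-fold higher number from compound 1 to compound 3 (0.06 log units; within the scatter) on the same saturated chain carbon bound to a carbonyl carbon. The earlier pair only showed one substituent exchanged for another, whereas this place has now been read with no substituent at all: the change from (1H-imidazol-1-yl)methyl to methyl takes away a whole five-membered aromatic ring, and the number stays within the scatter, so neither group is required for the effect seen on this read-out. No measurement available here explains why the number holds across these three compounds.

The compounds shown carry only acetamido, 1H-imidazol-1-yl or hydrogen on this carbon, so it remains open whether a dimethylamino group, a carboxylic acid or a longer chain there would move the number beyond the scatter. The shared core is the same in all three compounds, which leaves open how far changes elsewhere in the structure would shift the dose needed.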